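Thioether variation on the shared core, gastric cell growth

The source may report more compounds than this note shows. Statements on the series, on what has been measured and on what is new or still open speak of the compounds shown alone.

Measured in a functional assay on HGC-27 cells (Homo sapiens) for inhibition, read by MTT assay, with a stated time of 72 h; a higher number here means a weaker inhibitor, a lower number a stronger inhibitor:
compound 1 `CCCSc1nc2nc(C)cc(N3CC[C@@H](C)[C@@H](N(C)c4ncnc5[nH]ccc45)C3)n2n1` gives 20900 nM
compound 2 `C=CCSc1nc2nc(C)cc(N3CC[C@@H](C)[C@@H](N(C)c4ncnc5[nH]ccc45)C3)n2n1` gives 35200 nM

Among the compounds with values here, compound 2 holds the higher of the two numbers; the only measured step is a 1.7-fold higher number from compound 1 to compound 2 (0.23 log units; within the scatter), which stays within the scatter. Compound 3 `Cc1cc(N2CC[C@@H](C)[C@@H](N(C)c3ncnc4[nH]ccc34)C2)n2nc(SCc3ccc(Cl)cc3)nc2n1` differs from compound 2 by 4-chlorophenyl in place of vinyl on a saturated chain carbon bound to a sulfur. Within the data shown here, that earlier step altered the same chain and moved little, but no measured step covers an aromatic ring entering at this place, so its bearing is weak. No step beyond the scatter is expected in this assay for compound 3, which is expected at a 1.2-fold lower number from compound 2 to compound 3 (0.07 log units; within the scatter). Compound 3 is estimated at 30000 nM, within 8000 nM to 100000 nM.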

Compound 3, half-maximal inhibitory concentration: 18400 nM
Estimate against measurement, compound 3: 1.6-fold (0.21 log units) above; measured number inside the range.
By their numbers in this assay, from the lowest: compounds 3, 1 and 2 (each within the scatter of the next).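

In this assay an aromatic ring enters on the saturated chain carbon bound to a sulfur with no step beyond the scatter, 4-chlorophenyl in place of vinyl (a 1.9-fold lower number from compound 2 to compound 3 (0.28 log units; within the scatter)) and in place of ethyl (a 1.1-fold lower number from compound 1 to compound 3 (0.06 log units; within the scatter)). The allyl, propyl and 4-chlorobenzyl thioethers therefore all stand within the scatter of one another, even with the larger group at this place. Nothing available explains this flat response.

Open, as far as these compounds go, is whether an amine or a carboxylic acid on this chain would give a step beyond the scatter. Also open, from the compounds shown here alone, is whether methoxy in place of the chlorine on the ring would do so.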